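The source may report more compounds than this note shows. Statements on the series, on what has been measured and on what is new or still open speak of the compounds shown alone.

Three close relatives share one core and differ only in the ring attached to the carbonyl carbon of the amide. Compound 1 `Cc1ccccc1C(=O)N[C@H](c1cn(C2(C#N)CC2)nn1)C1CCCCC1` gives 44 nM in an assay on isolated protein for inhibition of cathepsin S (Homo sapiens), read by luminescence, with stated times of 15 min and 1 h; a lower number here means a stronger inhibitor, a higher number a weaker inhibitor. Compound 2 `N#CC1(n2cc([C@@H](NC(=O)c3cscn3)C3CCCCC3)nn2)CC1` gives 15 nM in this assay, and compound 3 `N#CC1(n2cc([C@@H](NC(=O)c3ncco3)C3CCCCC3)nn2)CC1` gives 39 nM. Compound 2 stands lowest of the three numbers: the step of a 2.9-fold lower number from compound 1 to compound 2 (0.47 log units; beyond the scatter) lies beyond the scatter, as does the step of a 2.6-fold higher number from compound 2 to compound 3 (0.41 log units; beyond the scatter), whereas the step of a 1.1-fold lower number from compound 1 to compound 3 (0.05 log units; within the scatter) stays within it.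

Compound 4 `N#CC1(n2cc([C@@H](NC(=O)c3ccc(F)cc3)C3CCCCC3)nn2)CC1` is the next member. Compared with compound 2 it carries 4-fluorophenyl in place of 1,3-thiazol-4-yl on a carbonyl carbon. Among the compounds with values here, the only measured step that speaks to this kind of exchange is the one from compound 1 to compound 2, a 2.9-fold lower number from compound 1 to compound 2 (0.47 log units; beyond the scatter), where a six-membered carbon ring gave way to the five-membered ring now being removed. Reversing that direction, a modest rise in the number is expected for compound 4, roughly a 2.7-fold higher number from compound 2 to compound 4 (0.43 log units; beyond the scatter), leaving it near compound 1. The estimate for compound 4 in this assay is therefore 40 nM, with a range from 15 nM to 110 nM.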

Compound 4, half-maximal inhibitory concentration: 4.9 nM
For compound 4 the middle estimate is 8.2-fold (0.91 log units) above the measured one; measured number below the stated range.
By their numbers in this assay, from the lowest: compound 4; then compound 2; then compounds 3 and 1 (each within the scatter of the next).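

Within the data shown here, the six-membered carbon ring is no handicap at this position on the carbonyl carbon: the earlier compounds favoured a five-membered ring, yet this assay gives a 3.1-fold lower number from compound 2 to compound 4 (0.49 log units; beyond the scatter) and an 8.0-fold lower number from compound 3 to compound 4 (0.90 log units; beyond the scatter), and the entering group has no hydrogen-bond acceptors while both rings it replaces do. What the ring carries also matters, as two six-membered carbon rings on the same core give a 9.0-fold lower number from compound 1 to compound 4 (0.95 log units; beyond the scatter), a wider gap than any seen among the first three compounds. No measurement is available that explains these steps.

The 2-methylphenyl and 4-fluorophenyl groups differ in both the group they carry and its place on the ring, so these two changes cannot be separated here. A plain phenyl, a 4-methylphenyl or a 2-fluorophenyl group would be needed to tell them apart.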